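Moving from 4-hydroxyphenyl to 2-methoxyphenyl on a sulfonyl sulfur

The source may hold more compounds than are shown below. What is called first, only, known or untested is meant among the compounds shown, and "the series" means these compounds.

Of the compounds shown here, two sharing one core have been measured so far: compound 1 (`O=S(=O)(Nc1ccc(-c2nc3ccccc3o2)cc1)c1ccc(Cl)s1`) and compound 2 (`O=S(=O)(Nc1ccc(-c2nc3ccccc3o2)cc1)c1ccc(O)cc1`). In an ADME assay on HEK293 cells (Homo sapiens) for cytotoxicity, read by resazurin assay, with a stated time of 48 h (a lower number here means that less compound is tolerated, a higher number that more compound is tolerated), compound 1 gives > 100000 nM, which is a limit of the assay and not a number. In this assay compound 2 gives > 100000 nM, which is likewise a limit and not a number. Compound 2 therefore has no number of its own, and the record so far is the limit of > 100000 nM in this assay, at which 2 of the 2 values shown sit.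

Compound 3 (`COc1ccccc1S(=O)(=O)Nc1ccc(-c2nc3ccccc3o2)cc1`) has not yet been measured. It carries 2-methoxyphenyl in place of 4-hydroxyphenyl on a sulfonyl sulfur.

For the measured compounds named here, only one measured step bears on this change, a replacement at the same place on the sulfonyl sulfur: a step that the two limits leave unreadable from compound 1 to compound 2. It offers no size to carry forward. Going by the values given here, with that step as the only guide, no change beyond the scatter is expected in this assay, and no direction can be given. The expected size is a number no higher from compound 2 to compound 3 (the limit leaves the size open). For compound 3 the estimated value is 100000 nM, with an expected range from 40000 nM to 200000 nM.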

Compound 3, half-maximal cytotoxic concentration: > 100000 nM
Compound 3 was reported as a limit; the forecaster's own chance of this, stated with the estimate: 80%; the middle value sits exactly at the limit.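

Compound 1, compound 2 and compound 3 all stand at a limit of the assay rather than at a number, so no new step can be read among them in this assay: the limit of > 100000 nM in this assay, at which 3 of the 3 values shown sit. The compounds shown leave open how much of any of them is tolerated, and whether any replacement on the sulfonyl sulfur changes that.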